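The source may report more compounds than this note shows. Statements on the series, on what has been measured and on what is new or still open speak of the compounds shown alone.

Working notes on the series.

Of the compounds shown here, three carry a shared core and have been measured in a physicochemical assay for lipophilicity, at pH 7.4; on this read-out higher numbers stand for higher lipophilicity and lower numbers for lower lipophilicity. Compound 1 `CC(C)CN(Cc1ccccc1C(F)(F)F)S(=O)(=O)c1ccc2c(c1)C(O)CC(C1CCOCC1)O2` gives 4.23 in this assay. Compound 2 `Cc1cc(C(O)(C(F)(F)F)C(F)(F)F)ccc1N(CC(C)C)S(=O)(=O)c1ccc2c(c1)C(O)CC(C1CCOCC1)O2` gives 4.37 in this assay. Compound 3 `CCc1ccc(NS(=O)(=O)c2ccc3c(c2)C(O)CC(C2CCOCC2)O3)cc1`, which keeps a hydrogen on the sulfonamide nitrogen and a smaller aryl group, gives 2.59 in this assay, the lowest of the three numbers; compound 1 is the nearest to it and compound 2 the furthest, both beyond the scatter.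

Compound 4 `CCc1ccc(N(C2COC2)S(=O)(=O)c2ccc3c(c2)C(O)CC(C2CCOCC2)O3)cc1` has not yet been measured. It differs from compound 3 in one place: oxetan-3-yl in place of hydrogen on a sulfonamide nitrogen. Among the compounds with values here, no measured pair shows this exact change, so the expectation rests on the count of atoms entering and on the position of compound 3 alone. A modest rise in this assay is expected, from compound 3 to compound 4 of about a number 0.36 log units higher from compound 3 to compound 4 (beyond the scatter), roughly at the edge of the scatter. Compound 4 is accordingly estimated at 2.95 in this assay, with a range from 2.45 to 3.45.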

Compound 4, distribution coefficient: 2.63
Compound 4: the middle estimate sits 0.32 log units above what was measured; low and high end bracket the measured number.
By their numbers in this assay, from the lowest: compounds 3 and 4 (each within the scatter of the next); then compounds 1 and 2 (each within the scatter of the next).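

In this assay, oxetan-3-yl in place of hydrogen on a sulfonamide nitrogen comes out as a number 0.04 log units higher from compound 3 to compound 4 (within the scatter). Within the data shown here, this is the only one-place step so far, and it shows that, with the rest of compound 3 kept, the hydrogen on this nitrogen can give way to a four-membered non-aromatic ring with no shift beyond the scatter in this assay. No measurement at hand offers a reason for this result.

Going by these compounds, it remains open whether a carboxylic acid, an amine or a longer chain on this same nitrogen would also stay within the scatter of compound 3. On these data alone, it is equally open whether oxetan-3-yl in place of hydrogen would read the same with a different aryl group on the nitrogen.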